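Nitro in place of dimethylamino on the shared core

The compounds below may be only part of what the source reports. "The series", "measured", "known", "first", "only" and "open" are said of these compounds alone.

Three compounds share one core and differ only in one group on an aromatic carbon. Compound 1 `CCOC(=O)c1cccc(-c2ccc(OCC)cc2)c1` gives 87% in an assay on COS-7 cells for inhibition of patatin-like phospholipase domain-containing protein 2 (Mus musculus), tested at 200 uM; on this read-out lower numbers stand for less inhibition and higher numbers for more inhibition at the one concentration tested (going by the name of the read-out). Compound 2 `CCOC(=O)c1cccc(-c2ccc(O)cc2)c1` gives 77% in this assay, and compound 3 `CCOC(=O)c1cccc(-c2ccc(N(C)C)cc2)c1` gives 87% in this assay. Compound 3 thus sits level with compound 1, shown by no change at the digits printed from compound 1 to compound 3 (within the scatter), and its distance from compound 2, a number 10 percentage points higher from compound 2 to compound 3 (within the scatter), also lies within the scatter. Compound 4 `CCOC(=O)c1cccc(-c2ccc([N+](=O)[O-])cc2)c1` carries nitro in place of dimethylamino on an aromatic carbon. Because no change at the digits printed from compound 1 to compound 3 (within the scatter) and a number 10 percentage points higher from compound 2 to compound 3 (within the scatter) both stayed within the scatter for swaps at this same aromatic carbon, compound 4 is expected to show a number 7 percentage points lower from compound 3 to compound 4 (within the scatter), again within the scatter. Compound 4 is therefore estimated at 80%, with a range from 60% to 95%.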

Compound 4, a percentage reported as inhibition, at one concentration (the size of the read-out at that concentration, not a potency): 63%
Beside the measured number, compound 4's estimate is 17 percentage points above it; measured number inside the range.
By their numbers in this assay, from the lowest: compound 4; then compounds 2, 1 and 3 (each within the scatter of the next).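

In this assay this aromatic carbon proves sensitive to the group it carries, since nitro gives a number 24 percentage points lower from compound 3 to compound 4 (beyond the scatter) and a number 24 percentage points lower from compound 1 to compound 4 (beyond the scatter) and also a number 14 percentage points lower from compound 2 to compound 4 (beyond the scatter). Ethoxy, hydroxy and dimethylamino stay within the scatter of one another, so among these four compounds only nitro stands apart, and by modest steps. Nothing measured here accounts for this difference. Still open, on these data alone, is whether a nitrile, a carboxylic acid or a primary amine on this same carbon would fall with nitro or stay with the other three groups.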